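Swapping the benzyl group on compound 3

The source may hold more compounds than are shown below. What is called first, only, known or untested is meant among the compounds shown, and "the series" means these compounds.

In a functional assay on HeLa cells (Homo sapiens) for antiproliferative activity, read by MTT assay, with a stated time of 48 h (a lower number here means a stronger inhibitor, a higher number a weaker inhibitor), compound 1 `Fc1ccccc1CSc1nnc(-c2cnccn2)o1` gives 25300 nM, and compound 2 `Fc1ccc(CSc2nnc(-c3cnccn3)o2)c(F)c1` gives 26700 nM. Compound 3 `Clc1ccccc1CSc1nnc(-c2cnccn2)n1-c1ccccc1` reads > 50000 nM, which is a limit of the assay and not a number. So compound 3 has no exact starting value, and any comparison with it stays loose.

Compound 4 `Fc1ccc(CSc2nnc(-c3cnccn3)n2-c2ccccc2)c(F)c1` has not yet been measured. It differs from compound 3 in one place: 2,4-difluorophenyl in place of 2-chlorophenyl on a saturated chain carbon bound to a sulfur. In words, 2,4-difluorophenyl stands in place of 2-chlorophenyl on a saturated chain carbon bound to a sulfur.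

Among the compounds with values here, only one measured step bears on this change, and only in part. Putting fluoro in place of hydrogen on an aromatic carbon gave a 1.1-fold higher number from compound 1 to compound 2 (0.02 log units; within the scatter). Within the data shown here, that step was measured on a different core, and no measured pair removes 2-chlorophenyl itself. With so little to go on, no step beyond the scatter is expected in this assay, in either direction. The expected step is a number no higher from compound 3 to compound 4 (the limit leaves the size open). Compound 4 may well end up reported only as a limit too. If a number is reported, the estimate for compound 4 is 50000 nM, with an expected range of 25000 nM to 100000 nM.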

Compound 4, half-maximal inhibitory concentration: 12500 nM
Compound 4: middle estimate off by 4.0-fold (0.60 log units), on the high side, outside the stated range (below it).
By their numbers in this assay, from the lowest: compound 4; then compounds 1 and 2 (each within the scatter of the next). At a limit, above all of these: compound 3.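

On the core of compound 3, the benzyl group carried on the sulfur does change the result in this assay, with an at least 4.0-fold lower number from compound 3 to compound 4 (0.60 log units; beyond the scatter). Within the data shown here, this is the first step to lie beyond the scatter, whereas the earlier fluoro change on a different core, a 1.1-fold higher number from compound 1 to compound 2 (0.02 log units; within the scatter), stayed within it, so that step gave no sign of what this swap would do on this core. The reading for compound 3 is a limit of the assay and not a number, so the new step gives only a smallest size, and its true size stays unknown: the limit of > 50000 nM in this assay, at which 1 of the 4 values shown sits.

The swap takes away the chlorine and brings in two fluorines in one move, so the compounds shown cannot separate the loss of 2-chlorobenzyl from the gain of 2,4-difluorobenzyl, and a single fluorine on the same ring would be needed to begin pulling these apart. They also leave open how an unsubstituted benzyl, a benzyl bearing a methoxy group, or a longer chain between the sulfur and the ring would read on this core.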